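From 2,2,2-trifluoro-1-hydroxyethyl to methoxymethyl in compound 3

The compounds below may be only part of what the source reports. "The series", "measured", "known", "first", "only" and "open" are said of these compounds alone.

Within the data shown here, in an ADME assay on S9 fraction from liver (Rattus norvegicus) for metabolic stability, read by LC-MS, using NADPH, with a stated time of 60 min, tested at 10 uM (on this read-out higher numbers stand for a more stable compound and lower numbers for a less stable compound), compound 2 (`N#CC1(c2cc(CC(O)C(F)(F)F)cc(-c3ccnc4[nH]nc(C(F)(F)F)c34)c2)CC1`) gives 71% and holds the higher of the two numbers so far, while compound 1 (`N#CC1(c2cc(CCO)cc(-c3ccnc4[nH]nc(C(F)(F)F)c34)c2)CC1`) gives 17% on the same read-out. Compound 3 (`COCCc1cc(-c2ccnc3[nH]nc(C(F)(F)F)c23)cc(C2(C#N)CC2)c1`) keeps the shared core and alters only the side chain of compound 2 (methoxymethyl in place of 2,2,2-trifluoro-1-hydroxyethyl on a saturated chain carbon bound to an aromatic carbon) on a saturated chain carbon bound to an aromatic carbon.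

Among the measured compounds shown here, only one measured step bears on this change, and it is large (a number 54 percentage points higher from compound 1 to compound 2 (beyond the scatter)) and came with a trifluoromethyl that compound 3 no longer carries. Methoxymethyl itself has not been measured on this core, so that step offers only partial guidance. Part of the gain seen in that step is expected to be lost, but how much remains uncertain. A sizeable fall beyond the scatter is therefore expected in this assay with the estimate being a number 33 percentage points lower from compound 2 to compound 3 (beyond the scatter) for this change. Compound 3 is estimated at 38% with an expected range of 15% to 65% on this read-out.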

Compound 3, percent of the compound remaining: 90%
The estimate for compound 3 lay 52 percentage points below the measured number, and the stated range ends below it.
By their numbers in this assay, from the lowest: compound 1; then compound 2; then compound 3.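

In this assay the change to methoxymethyl on a saturated chain carbon bound to an aromatic carbon cost nothing; the result is a number 19 percentage points higher from compound 2 to compound 3 (beyond the scatter) and shows that a trifluoromethyl on this side chain is not needed for a high number on this core. Methyl in place of hydrogen on an oxygen on a saturated carbon gave a number 73 percentage points higher from compound 1 to compound 3 (beyond the scatter), so the low number of compound 1 can be lifted at this side chain in two separate ways, by a trifluoromethyl on the chain carbon or by a methyl on the oxygen, and the second goes further than the first. What lies behind either step cannot be told, as nothing at hand bears on the cause.

The compounds shown leave open how far this side chain can be varied while the number stays high, for example with an ethoxy group, an amine or a carboxylic acid at its end. They also leave open whether a trifluoromethyl and the methyl on the oxygen, carried together on one chain, would add anything to what compound 3 already shows.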